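Amino for trifluoromethyl on a pyrazole urea: expected shift

The source may report more compounds than this note shows. Statements on the series, on what has been measured and on what is new or still open speak of the compounds shown alone.

Two ureas built on the same core have been read in an assay on isolated protein for inhibition of Ephrin type-A receptor 2 (Homo sapiens), read by thermal shift assay, tested at 10 uM; on this read-out lower numbers stand for weaker stabilisation of the target and higher numbers for stronger stabilisation of the target against heat. Compound 1 `COc1cccc(NC(=O)Nc2cc(C(C)(C)C)nn2-c2ccccc2)c1` gives 1.8 degrees C, and compound 2 `CC(C)(C)c1cc(NC(=O)Nc2ccc(Cl)cc2)n(-c2ccc(C(F)(F)F)cc2)n1` gives 0.6 degrees C, which is the lower of the two numbers, with compound 1 sitting a step above it that lies beyond the scatter. Compound 3 `CC(C)(C)c1cc(NC(=O)Nc2ccc(Cl)cc2)n(-c2ccc(N)cc2)n1` has not yet been measured. It differs from compound 2 in one place: amino in place of trifluoromethyl on an aromatic carbon. Within the data shown here, no measured pair in this set isolates that change, so the size of its effect is unknown. Compound 3 is expected to stay close to compound 2, with a step of a number 0.40 degrees C higher from compound 2 to compound 3 (within the scatter) that, if present at all, is estimated to fall within the usual scatter. The estimate for compound 3 in this assay is 1 degrees C, with a range from -0.5 degrees C to 2.5 degrees C.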

Compound 3, shift of the target's melting temperature: 2 degrees C
Estimate against measurement, compound 3: 1.0 degrees C below, within the range that was stated.
By their numbers in this assay, from the lowest: compound 2; then compounds 1 and 3 (each within the scatter of the next).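

In this assay, amino in place of trifluoromethyl on an aromatic carbon, para to a large group, gives a number 1.4 degrees C higher from compound 2 to compound 3 (beyond the scatter). Among these compounds, this is the first pair in the set that differs in one place only, so it shows that the group held at this position on the ring can alter the read-out by more than the usual scatter, with the rest of the molecule unchanged. The step is modest, and in the direction of stronger stabilisation of the target against heat on going from 4-(trifluoromethyl)phenyl to 4-aminophenyl.

Going by these compounds, whether a hydroxyl, a carboxylic acid, an acetamide or a dimethylamino group at the same place would match amino, or fall back towards trifluoromethyl, stays open, as does whether the step would hold on another urea partner. Nothing shown bears on why the number moves.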